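Notes on amine-nitrogen substitution in a growth-inhibition series

The source may hold more compounds than are shown below. What is called first, only, known or untested is meant among the compounds shown, and "the series" means these compounds.

Measured so far:
compound 1 `COc1ccc(CN2CCN(c3nc(Nc4ccc(C#N)c(C(F)(F)F)c4)nc(Oc4ccnc5ccccc45)n3)CC2)c(OC)c1OC` — > 100000 nM
compound 2 `CC(C)N1CCN(c2nc(Nc3ccc(C#N)c(C(F)(F)F)c3)nc(Oc3ccnc4ccccc34)n2)CC1` — > 100000 nM

In a functional assay on DU-145 cells (Homo sapiens) for cytotoxicity, read by sulforhodamine B assay, with a stated time of 48 h (on this read-out higher numbers stand for weaker inhibition of growth and lower numbers for stronger inhibition of growth), compound 1 gives > 100000 nM, which is a limit of the assay and not a number. In this assay compound 2 gives > 100000 nM, again a limit rather than a number. Compound 2 thus stands at the limit, as does every value shown so far (the limit of > 100000 nM in this assay, at which 2 of the 2 values shown sit). For the measured compounds named here, no step between measured compounds can be computed, since neither gives a number.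

Compound 3 `COc1ccc(N2CCN(c3nc(Nc4ccc(C#N)c(C(F)(F)F)c4)nc(Oc4ccnc5ccccc45)n3)CC2)cc1` remains to be measured in this assay. It differs from compound 2 in one place: 4-methoxyphenyl in place of isopropyl on an amine nitrogen in a ring. With both measured compounds sitting at the limit, the data give no direction for this change. The expected step is a number no higher from compound 2 to compound 3 (the limit leaves the size open), that is, none beyond the scatter. Compound 3 is estimated at 100000 nM, with a range from 30000 nM to 300000 nM, and a limit rather than a number is the more likely outcome.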

Compound 3, concentration for total growth inhibition: > 100000 nM
Compound 3: only a limit was reported (the forecaster's own chance of this, stated with the estimate: 75%); the middle value lies on the limit itself.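

No step can be read from compound 2 to compound 3, because both sit at a limit of the assay and neither gives a number: the limit of > 100000 nM in this assay, at which 3 of the 3 values shown sit.

The compounds shown leave open whether any group on this amine nitrogen in the ring would give a readable number, and in which direction such a change would run.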